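Aryl swap on the triazole nitrogen: compound 2 to compound 4

This account rests on a few compounds, and the source may have more. Where it says the series, first, only, none or still open, it means among the compounds named here.

In a functional assay on LoVo cells (Homo sapiens) for inhibition, read by MTT assay, with a stated time of 24 h (on this read-out lower numbers stand for stronger inhibition and higher numbers for weaker inhibition), compound 2 `CC1(C)[C@H]2CC[C@]1(C)N(Cc1cn(-c3cccc(C#N)c3)nn1)C(=O)C2` gives 320 nM, the highest number of the three measured. Compound 1 `CC1(C)[C@H]2CC[C@]1(C)N(Cc1cn(-c3ccccc3C#N)nn1)C(=O)C2` gives 140 nM and compound 3 `CC1(C)[C@H]2CC[C@]1(C)N(Cc1cn(-c3ccc(F)cc3)nn1)C(=O)C2` gives 40 nM. The shared core is kept throughout; only the aryl on the triazole nitrogen changes. The step of a 2.3-fold higher number from compound 1 to compound 2 (0.36 log units; beyond the scatter) and the step of an 8.0-fold lower number from compound 2 to compound 3 (0.90 log units; beyond the scatter) both show this aryl moving the read-out beyond the scatter. Among the compounds with values here, compound 4 `COc1ccccc1-n1cc(CN2C(=O)C[C@@H]3CC[C@@]2(C)C3(C)C)nn1` differs from compound 2 as follows: 2-methoxyphenyl in place of 3-cyanophenyl on an aromatic nitrogen No measured step covers a methoxy group, so the expectation rests on the two steps above. A lower number is expected, estimated as a 2.7-fold lower number from compound 2 to compound 4 (0.43 log units; beyond the scatter). Compound 4 is thus expected at 120 nM, with a range of 40 nM to 360 nM.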

Compound 4, half-maximal inhibitory concentration: 70 nM
The estimate for compound 4 lay 1.7-fold (0.23 log units) above the measured number, within the range that was stated.
By their numbers in this assay, from the lowest: compounds 3, 4 and 1 (each within the scatter of the next, the first and the last beyond it); then compound 2.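

Replacing 3-cyanophenyl with 2-methoxyphenyl gives a 4.6-fold lower number from compound 2 to compound 4 (0.66 log units; beyond the scatter) and shows that a methoxy group on this aryl can also bring the number down from that of compound 2. Replacing 4-fluorophenyl with 2-methoxyphenyl gives a 1.8-fold higher number from compound 3 to compound 4 (0.24 log units; within the scatter) and so does not separate that pair. Methoxy in place of cyano on the same aromatic carbon gives a 2.0-fold lower number from compound 1 to compound 4 (0.30 log units; within the scatter) and does not separate that pair either. On these data alone, how an amine or a carboxylic acid on this aryl would read out remains open. Nothing available explains these steps.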